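From 1-Hydroxyethyl to (Methoxycarbonyl)methyl: What Should Change?

The compounds below may be only part of what the source reports. "The series", "measured", "known", "first", "only" and "open" are said of these compounds alone.

Measured in a functional assay on HCT-8 cells (Homo sapiens) for cytotoxicity, read by MTT assay, with a stated time of 24 h; a higher number here means a weaker inhibitor, a lower number a stronger inhibitor:
- compound 1 `COC(=O)[C@H](NC(=O)Cn1cc(C2=C(c3c[nH]c4ccccc34)C(=O)N(C)C2=O)c2ccccc21)[C@@H](C)O` gives 23400 nM
- compound 2 `COC(=O)CC[C@@H](NC(=O)Cn1cc(C2=C(c3c[nH]c4ccccc34)C(=O)N(C)C2=O)c2ccccc21)C(=O)OC` gives 29200 nM
- compound 3 `COC(=O)[C@@H](CC(C)C)NC(=O)Cn1cc(C2=C(c3c[nH]c4ccccc34)C(=O)N(C)C2=O)c2ccccc21` gives 37800 nM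

Compound 1 stands level with the other two compounds, and no order can be read among the three values. The next compound, compound 4 `COC(=O)C[C@@H](NC(=O)Cn1cc(C2=C(c3c[nH]c4ccccc34)C(=O)N(C)C2=O)c2ccccc21)C(=O)OC`, keeps the core of compound 1 and alters one group. The change is (methoxycarbonyl)methyl in place of 1-hydroxyethyl on a saturated chain carbon bound to an amide-type nitrogen and a carbonyl carbon, with (methoxycarbonyl)methyl in place of 1-hydroxyethyl on a saturated chain carbon bound to an amide-type nitrogen and a carbonyl carbon.

Compound 2 is the best guide, as its 2-(methoxycarbonyl)ethyl is the most similar measured group, and the data show a 1.2-fold higher number from compound 1 to compound 2 (0.10 log units; within the scatter). Compound 3 carries isobutyl at that place, and the data show a 1.6-fold higher number from compound 1 to compound 3 (0.21 log units; within the scatter). Both steps are small, and neither goes beyond the scatter. No step beyond the scatter is therefore expected in this assay, only an estimated 1.2-fold higher number from compound 1 to compound 4 (0.08 log units; within the scatter). For compound 4 the expected value is 28000 nM, with an estimated range from 15000 nM to 52000 nM.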

Compound 4, half-maximal inhibitory concentration: 23400 nM
For compound 4 the middle estimate is 1.2-fold (0.08 log units) above the measured one, within the range that was stated.
By their numbers in this assay, from the lowest: compounds 1, 4, 2 and 3 (each within the scatter of the next).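

In this assay the replacement of 1-hydroxyethyl by (methoxycarbonyl)methyl on the saturated chain carbon bound to an amide-type nitrogen and a carbonyl carbon gives no change at the digits printed from compound 1 to compound 4 (within the scatter), so this hydrogen-bond donor can go without any visible cost here. Shortening the ester-bearing chain also stays within the scatter, with a 1.2-fold lower number from compound 2 to compound 4 (0.10 log units; within the scatter), and the comparison with the branched hydrocarbon chain does too, with a 1.6-fold lower number from compound 3 to compound 4 (0.21 log units; within the scatter). Across these four compounds, then, no step at this position leaves the scatter, and none of them goes against that. Nothing available explains this flat result. Still open, on these data alone, is whether a carboxylic acid, an amine or a much longer chain on the same carbon would move the number beyond the scatter.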